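The compounds below may be only part of what the source reports. "The series", "measured", "known", "first", "only" and "open" are said of these compounds alone.

Measured so far in a functional assay (Oryctolagus cuniculus) for inhibition of platelet-activating factor receptor (Cavia porcellus); a lower number here means a stronger inhibitor, a higher number a weaker inhibitor:
Compound 1 `COc1cc(C(=O)N2CCN(C(=O)c3cc(OC)c(OC)c(OC)c3)C(COC(=O)C(C)(C)C)C2)cc(OC)c1OC`: 100 nM; 100 nM; 120 nM (3 entries)
Compound 2 `CCC(C)(C)NC(=O)OCC1CN(C(=O)c2cc(OC)c(OC)c(OC)c2)CCN1C(=O)c1cc(OC)c(OC)c(OC)c1`: 320 nM
Compound 3 `CCC(CC)NC(=O)OCC1CN(C(=O)c2cc(OC)c(OC)c(OC)c2)CCN1C(=O)c1cc(OC)c(OC)c(OC)c1`: 130 nM

Among the two compounds with a single number, compound 3 gives the lowest one; its nearest neighbour is compound 2, and the step of a 2.5-fold lower number from compound 2 to compound 3 (0.39 log units; beyond the scatter) is modest but beyond the scatter. Compound 1, with an ester in place of the carbamate, is known only from its repeated entries (the several entries of compound 1 in this assay, 100 nM; 100 nM; 120 nM (3 entries)), which sit close to compound 3.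

The next compound, compound 4 `CCCN(CCC)C(=O)OCC1CN(C(=O)c2cc(OC)c(OC)c(OC)c2)CCN1C(=O)c1cc(OC)c(OC)c(OC)c1`, is made from compound 3 by the change (dipropylamino in place of (pentan-3-yl)amino on a carbonyl carbon). Among the measured compounds shown here, no measured step alters the carbamate in this way; the only step on this part of the molecule, a 2.5-fold lower number from compound 2 to compound 3 (0.39 log units; beyond the scatter), exchanges one alkyl group for another on the same nitrogen and moves the number only modestly. For the measured compounds named here, the present change is of a different kind, so its effect is uncertain; the small size of the one step on this side chain suggests that a large shift is unlikely. Compound 4 is therefore expected to give 200 nM, with a range of 80 nM to 500 nM. The expected step of a 1.5-fold higher number from compound 3 to compound 4 (0.19 log units; within the scatter) would lie near the edge of the scatter.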

Compound 4, half-maximal inhibitory concentration: 380 nM
Beside the measured number, compound 4's estimate is 1.9-fold (0.28 log units) below it, within the range that was stated.
By their numbers in this assay, from the lowest: compound 3; then compounds 2 and 4 (each within the scatter of the next).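

In this assay, among the compounds shown here, the first change on this carbonyl carbon that removes the amide hydrogen, dipropylamino in place of (pentan-3-yl)amino, gives a 2.9-fold higher number from compound 3 to compound 4 (0.47 log units; beyond the scatter) and so costs about as much as the earlier exchange of one alkyl group for another on the same nitrogen. The second comparison, a 1.2-fold higher number from compound 2 to compound 4 (0.07 log units; within the scatter), shows that dipropylamino and (1,1-dimethylpropyl)amino cannot be told apart here, even though compound 2 keeps the amide hydrogen as compound 3 does and compound 4 has none, so the presence of that hydrogen does not sort these three compounds: compound 3 stands apart from compound 4 while compound 2 does not. Nothing measured in this set gives a reason for these differences.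

The compounds shown leave open whether the hydrogen itself matters, a question that a methyl group on the nitrogen of compound 3 would address more directly than a change that also alters the chains. They also leave open how shorter dimethylamino, a cyclic amine such as piperidin-1-yl, or a carboxylic acid at the end of a longer chain would behave at this position.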